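Methoxy on the pendant phenyl, second occurrence

This account rests on a few compounds, and the source may have more. Where it says the series, first, only, none or still open, it means among the compounds named here.

Compound 1 `COc1ccc(C2CC(c3ccccc3)=NN2C2=NC(=O)/C(=C3\C(=O)Nc4ccc(Br)cc43)S2)cc1` and compound 2 `COc1ccc(C2=NN(C3=NC(=O)/C(=C4\C(=O)Nc5ccc(Br)cc54)S3)C(c3ccc(OC)cc3)C2)cc1` share one core, and compound 2 differs from compound 1 only by methoxy in place of hydrogen on an aromatic carbon. In a functional assay on cells (Cancer cell lines, Homo sapiens) for cytotoxicity, read by sulforhodamine B assay, with a stated time of 48 h (a lower number here means a stronger inhibitor of growth, a higher number a weaker inhibitor of growth), compound 1 gives 480 nM, and compound 2 gives 480 nM, so the step of no change at the digits printed from compound 1 to compound 2 (within the scatter). Compound 3 `O=C1N=C(N2N=C(c3ccccc3)CC2c2ccc(Cl)cc2)S/C1=C1/C(=O)Nc2ccccc21` rests on a core that differs from that of compound 1; the difference between the two cores is not broken down here. In this assay compound 3 gives 910 nM, which sits within the scatter of both compound 1 and compound 2. Within the data shown here, compound 4 `COc1ccc(C2=NN(C3=NC(=O)/C(=C4\C(=O)Nc5ccccc54)S3)C(c3ccc(Cl)cc3)C2)cc1` has not been measured in this assay; it differs from compound 3 by methoxy in place of hydrogen on an aromatic carbon, the same change as that seen from compound 1 to compound 2, and no other pair shows this change. Among the measured compounds shown here, the step of a 1.1-fold lower number from compound 3 to compound 4 (0.03 log units; within the scatter) is expected to be small, because no change at the digits printed from compound 1 to compound 2 (within the scatter) on the other core, though with only one prior example the expectation is loose. Compound 4 is therefore estimated at 850 nM in this assay, with the likely range from 400 nM to 1800 nM.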

Compound 4, concentration for total growth inhibition: 100000 nM
The estimate for compound 4 lay 120-fold (2.07 log units) below the measured number, outside the stated range (above it).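

Methoxy in place of hydrogen, phenyl to 4-methoxyphenyl, gives a 110-fold higher number from compound 3 to compound 4 (2.04 log units; beyond the scatter) in this assay, so on the core of compound 3 this change is far from neutral. The result of this change on one core therefore did not carry over to the other core in this series: the same change on two cores in this assay, no change at the digits printed (within the scatter) from compound 1 to compound 2 and a 110-fold higher number (2.04 log units; beyond the scatter) from compound 3 to compound 4, 110-fold (2.04 log units) apart, beyond the scatter of two such steps

Two pairs do not show which difference between the cores sets this gap, nor whether the large step on the core of compound 3 is general for that core or particular to methoxy.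

The compounds shown leave open how other groups on the same aromatic carbon, such as hydroxy, an amine or a longer chain like ethoxy, behave on each of the two cores. They also leave open whether a second pair on the core of compound 3, carrying methoxy on a different pendant ring, would repeat the step seen here.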